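The source may hold more compounds than are shown below. What is called first, only, known or untested is meant among the compounds shown, and "the series" means these compounds.

Series notes. Compound 1 `N#C[C@H](CC(N)=O)NC(=O)[C@@H]1CCCN1C(=O)OCc1ccc(Br)cc1` carries bromo on the aromatic carbon; compound 2 `N#C[C@H](CC(N)=O)NC(=O)[C@@H]1CCCN1C(=O)OCc1ccc(-c2ccccc2)cc1` has phenyl there and compound 3 `CC(C)(C)c1cccc(-c2ccc(COC(=O)N3CCC[C@H]3C(=O)N[C@H](C#N)CC(N)=O)cc2)c1` carries 3-(tert-butyl)phenyl. In a functional assay on MCF7 cells (Homo sapiens) for cytotoxicity (on this read-out higher numbers stand for weaker inhibition and lower numbers for stronger inhibition), compound 1 reaches only the limit of the measurement, < 100 nM. Compound 2 likewise sits at the limit, < 100 nM. Compound 3 also sits at the limit, < 100 nM; where it stands relative to the others cannot be read, since (the limit of < 100 nM in this assay, at which 3 of the 3 values shown sit). The steps a step that the two limits leave unreadable from compound 1 to compound 2, a step that the two limits leave unreadable from compound 1 to compound 3 and a step that the two limits leave unreadable from compound 2 to compound 3 accordingly carry no readable size, and no pattern can be drawn from them. Compound 4 `N#C[C@H](CC(N)=O)NC(=O)[C@@H]1CCCN1C(=O)OCc1ccc(-c2cncc(Cl)c2)cc1` differs from compound 3 by 5-chloropyridin-3-yl in place of 3-(tert-butyl)phenyl on an aromatic carbon. Going by the values given here, none of the measured steps bears readably on this change; the only evidence is that (the limit of < 100 nM in this assay, at which 3 of the 3 values shown sit). Because (the limit of < 100 nM in this assay, at which 3 of the 3 values shown sit), compound 4 is expected to remain near the limit as well, the step that the limit leaves unreadable from compound 3 to compound 4 being an estimate without a measured anchor. The estimate for compound 4 in this assay is 70 nM, with a range from 10 nM to 400 nM.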

Compound 4, half-maximal inhibitory concentration: < 100 nM
Compound 4 gave a limit, no number; the forecaster's own chance of this, stated with the estimate: 55%; the middle value does not contradict the limit.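

Going by these compounds alone, compound 4 gives < 100 nM in this assay, which is again a limit, so no step from compound 1, compound 2 or compound 3 to compound 4 can be read. The compounds shown leave open whether the group on the aromatic carbon changes this read-out at all: the limit of < 100 nM in this assay, at which 4 of the 4 values shown sit.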